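Removing a Trifluoromethyl Group: Tolerance of Cultured Cells

This account rests on a few compounds, and the source may have more. Where it says the series, first, only, none or still open, it means among the compounds named here.

Compound 1, `Cn1cc(SCC(=O)N(Cc2ccccc2)Cc2ccccc2)c2ccccc21`: 91200 nM
Compound 2, `Cn1cc(SCC(=O)NCc2ccc(C(F)(F)F)cc2)c2ccccc21`: > 100000 nM

Both compounds share one core and were tested in an ADME assay on HEK-293T cells (Homo sapiens) for cytotoxicity, read by CCK-8 assay, with a stated time of 24 h; a lower number here means that less compound is tolerated, a higher number that more compound is tolerated. Compound 1 gives a numerical result, 91200 nM. For compound 2 the read-out is a limit of the assay rather than a number, > 100000 nM. Of the two values shown, one sits at that limit, as the record states: the limit of > 100000 nM in this assay, at which 1 of the 2 values shown sits. So compound 2 stands at the edge of what this assay can report, with no number of its own, and no step between compound 1 and compound 2 can be sized.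

The next compound, compound 3, `Cn1cc(SCC(=O)NCc2ccccc2)c2ccccc21`, differs from compound 2 in one place: hydrogen in place of trifluoromethyl on an aromatic carbon.

Whether that change moves the read-out cannot be judged from the pair shown, so the step from compound 2 to compound 3 in this assay is expected to be small, at most within the usual scatter, in either direction: a number no higher from compound 2 to compound 3 (the limit leaves the size open). Compound 3 is therefore estimated at 100000 nM, with a plausible range from 50000 nM to 200000 nM, and a fair chance that the assay again reports only a limit.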

Compound 3, half-maximal cytotoxic concentration: 95500 nM
Compound 3: the middle estimate sits 1.0-fold (0.02 log units) above what was measured; measured number inside the range.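

In this assay, compound 3, which carries hydrogen on the aromatic carbon where compound 2 carries trifluoromethyl, gives a measurable number, and the change reads as an at least 1.0-fold lower number from compound 2 to compound 3 (0.01 log units; that floor lies within the scatter), so at this position the cells tolerate the hydrogen compound at about the top of the range the test can report. As far as these compounds go, compound 2 remains a limit of the assay and not a number, so only the smallest possible size of that step is known, and the true size stays open: the limit of > 100000 nM in this assay, at which 1 of the 3 values shown sits. The result also links compound 3 to compound 1 at a second place on the shared core, where hydrogen in place of benzyl on the amide-type nitrogen gives a 1.0-fold higher number from compound 1 to compound 3 (0.02 log units; within the scatter), so this second change leaves the read-out within the usual scatter as well.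

The compounds shown leave open whether an amine or a carboxylic acid on that same aromatic carbon would keep the read-out this high. They also leave open how far a methyl group or a longer chain on the amide-type nitrogen would move it, if at all.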